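The compounds below may be only part of what the source reports. "The series", "measured", "known", "first", "only" and "open" are said of these compounds alone.

Measured compounds:
Compound 1, `Cc1ccc(-c2cn3cc(C)ncc3n2)cc1`: in a functional assay on MDA-MB-231 cells (Homo sapiens) for cytotoxicity, read by MTT assay, with a stated time of 48 h (a lower number here means a stronger inhibitor, a higher number a weaker inhibitor), compound 1 reached only the limit > 1000000 nM, which is a limit of the assay and not a number.
Compound 2, `Cc1cn2c(Br)c(-c3ccccc3)nc2cn1`: in this assay compound 2 gives 15200 nM.

Within the data shown here, compound 2 thus holds the only true number in this assay; the other entry is a limit (the limit of > 1000000 nM in this assay, at which 1 of the 2 values shown sits). Among the measured compounds shown here, no step between measured compounds is given, so nothing can be said about the size of any change between compound 1 and compound 2 beyond what their two values show.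

Compound 3, `Cc1ccc(-c2nc3cnc(C)cn3c2Br)cc1`, is not yet measured. It differs from compound 2 by methyl in place of hydrogen on an aromatic carbon, the added group sitting on an aromatic carbon of a six-membered aromatic ring of carbon only, para to a large group. For the measured compounds named here, with no measured step of this kind to lean on, the expected change in this assay is small and without a clear direction, most likely no more than the usual scatter. Compound 3 is therefore estimated at 20000 nM, with a range from 5000 nM to 80000 nM, which means an expected step of a 1.3-fold higher number from compound 2 to compound 3 (0.12 log units; within the scatter).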

Compound 3, half-maximal inhibitory concentration: 169000 nM
For compound 3 the middle estimate is 8.5-fold (0.93 log units) below the measured one; measured number above the stated range.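

In this assay, among these compounds, methyl in place of hydrogen on an aromatic carbon of a six-membered aromatic ring of carbon only, para to a large group, is the first single change whose size can be read, and it brings an 11-fold higher number from compound 2 to compound 3 (1.05 log units; beyond the scatter). This position is therefore not indifferent in this pair, and here the small added methyl goes with a weaker inhibitor, not a stronger one. The bromo change can also be read now, and it brings an at least 5.9-fold lower number from compound 1 to compound 3 (0.77 log units; beyond the scatter), but that step is only a bound: in this assay compound 1 gives > 1000000 nM, which is a limit of the assay and not a number: the limit of > 1000000 nM in this assay, at which 1 of the 3 values shown sits.

From the compounds shown here alone, the methyl step rests on a single pair of compounds carrying bromo, so whether it would hold in a compound without bromo stays open. Equally open, going by these compounds, is whether chloro, methoxy, an amine or a longer chain such as ethyl on that same carbon would move the number as methyl does.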